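The source may report more compounds than this note shows. Statements on the series, on what has been measured and on what is new or still open speak of the compounds shown alone.

Values in a functional assay on HCT-116 cells (Homo sapiens) for antiproliferative activity, with a stated time of 72 h; a higher number here means a weaker inhibitor, a lower number a stronger inhibitor:
compound 1 `O=C(COc1ccc(CN2CC=C(c3c[nH]c4ccc(F)cc34)CC2)cc1)NO` gives 949 nM
compound 2 `Cc1ccc2[nH]cc(C3=CCN(Cc4ccc(OCC(=O)NO)cc4F)CC3)c2c1` gives 1450 nM

Compound 2 at 1450 nM stands within the usual scatter of compound 1, so these two numbers set no order between them.

Compound 3 (`Cc1ccc2[nH]cc(C3=CCN(Cc4ccc(OCC(=O)NO)cc4)CC3)c2c1`) differs from compound 2 in one place, with hydrogen in place of fluoro on an aromatic carbon. That carbon is ortho to a large group and meta to a (hydroxycarbamoyl)methoxy group. Going by the values given here, no measured pair isolates this change, so the expectation starts from compound 2 at 1450 nM alone. In this assay no step beyond the scatter is expected, and no firm direction can be given. The estimated step is a 1.3-fold lower number from compound 2 to compound 3 (0.12 log units; within the scatter) and is expected to stay within the scatter. For compound 3 the expected value is 1100 nM with an estimated range from 450 nM to 2700 nM for the coming measurement.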

Compound 3, half-maximal inhibitory concentration: 632 nM
The estimate for compound 3 lay 1.7-fold (0.24 log units) above the measured number; the measured number falls inside the stated range.
By their numbers in this assay, from the lowest: compounds 3, 1 and 2 (each within the scatter of the next, the first and the last beyond it).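

In this assay the change of fluoro to hydrogen on the aromatic carbon ortho to a large group and meta to a (hydroxycarbamoyl)methoxy group gives a modest step (a 2.3-fold lower number from compound 2 to compound 3 (0.36 log units; beyond the scatter)), the first in the series to pass the scatter. The other single-place pair, with methyl in place of fluoro on an aromatic carbon, gives a step that sets no order between its two compounds (a 1.5-fold lower number from compound 1 to compound 3 (0.18 log units; within the scatter)). Nothing measured here accounts for the fluoro-to-hydrogen step.

Open, from the compounds shown here alone, is how this carbon responds to groups other than fluoro and hydrogen, such as chloro, methoxy or an amine. Also open, going by these compounds, is whether the fluoro-to-hydrogen step recurs on the core of compound 1, and how a longer chain in place of the (hydroxycarbamoyl)methoxy group would read in this assay.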